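The source may hold more compounds than are shown below. What is called first, only, known or untested is meant among the compounds shown, and "the series" means these compounds.

Measured so far in an ADME assay on a cell-free system (plasma, Rattus norvegicus) for metabolic stability, read by LC-MS, with a stated time of 120 min, tested at 200 uM; a lower number here means that the compound disappears faster, a higher number that the compound lasts longer:
- compound 1 `N[C@@H](CC(=O)OC[C@H]1O[C@@H](n2cc(F)c(=O)[nH]c2=O)C[C@@H]1O)C(=O)O`: 2.5 h
- compound 2 `N[C@@H](CCC(=O)O[C@H]1C[C@H](n2cc(F)c(=O)[nH]c2=O)O[C@@H]1CO)C(=O)O`: 1.62 h
- compound 3 `CC(C)[C@H](N)C(=O)O[C@H]1C[C@H](n2cc(F)c(=O)[nH]c2=O)O[C@@H]1CO`: 1.09 h

Compound 1 and compound 2 cannot be told apart within the usual scatter, whereas compound 3 lies beyond the scatter from compound 1. The step to the unmeasured compound 4 `CC(C)[C@H](N)C(=O)OC[C@H]1O[C@@H](n2cc(F)c(=O)[nH]c2=O)C[C@@H]1O` is 1-amino-2-methylpropyl in place of 2-amino-2-carboxyethyl on a carbonyl carbon. Among the compounds with values here, one measured step bears on it: a 1.5-fold lower number from compound 2 to compound 3 (0.17 log units; within the scatter), where the same entering group replaced a longer amino acid chain at a different position on the shared core, and the change stayed within the scatter. On that basis compound 4 is expected to show only a small drop in this assay, if any, with a 1.4-fold lower number from compound 1 to compound 4 (0.14 log units; within the scatter). The estimate for compound 4 is 1.8 h, with a range from 1 h to 3.2 h.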

Compound 4, half-life: 1.31 h
For compound 4 the middle estimate is 1.4-fold (0.14 log units) above the measured one; the measured number falls inside the stated range.
By their numbers in this assay, from the lowest: compounds 3, 4, 2 and 1 (each within the scatter of the next, the first and the last beyond it).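

In this assay the new step is a 1.9-fold lower number from compound 1 to compound 4 (0.28 log units; within the scatter) and so places 1-amino-2-methylpropyl and 2-amino-2-carboxyethyl on this carbonyl carbon within the usual scatter of each other. Within the data shown here, the earlier step with the same entering group is a 1.5-fold lower number from compound 2 to compound 3 (0.17 log units; within the scatter) and concerns a different position and a longer leaving chain, so this is the first reading of the change at this position. No measurement shown here offers a cause for this result.

From the compounds shown here alone, whether a plain ethyl group without an amine on this carbonyl carbon would also stay within the scatter of compound 1 remains open.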